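Replacing Cyclohexyl with Hydroxymethylphenyl in Adenosine Deaminase Inhibitors

The source may report more compounds than this note shows. Statements on the series, on what has been measured and on what is new or still open speak of the compounds shown alone.

Compound 2 `C[C@H](O)[C@@H](CCC1CCCCC1)n1cnc2c(N)ncnc21` gives 1.9 nM in an assay on isolated protein for inhibition of adenosine deaminase (Bos taurus), with a stated time of 5 min (on this read-out higher numbers stand for weaker inhibition and lower numbers for stronger inhibition), the lower of the two numbers recorded so far; compound 1 `C[C@H](O)[C@@H](CCc1ccccc1C(F)(F)F)n1cnc2c(N)ncnc21` gives 6.2 nM, a gap beyond the usual scatter. Compound 3 `C[C@H](O)[C@@H](CCc1cccc(CO)c1)n1cnc2c(N)ncnc21` differs from compound 2 by 3-(hydroxymethyl)phenyl in place of cyclohexyl on a saturated chain carbon, three bonds along the chain from an aromatic nitrogen. Among the compounds with values here, no step between measured compounds matches this change, but compound 1, whose substituent is also aromatic, gives 6.2 nM, so a modest weakening is expected. The estimated step from compound 2 to compound 3 is a 2.6-fold higher number from compound 2 to compound 3 (0.42 log units; beyond the scatter). Compound 3 is expected to give 5 nM, with a range from 1.5 nM to 16 nM.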

Compound 3, inhibition constant: 4.6 nM
Compound 3: the middle estimate sits 1.1-fold (0.04 log units) above what was measured; the measured number falls inside the stated range.
By their numbers in this assay, from the lowest: compound 2; then compounds 3 and 1 (each within the scatter of the next).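

In this assay, replacing cyclohexyl with 3-(hydroxymethyl)phenyl gives a 2.4-fold higher number from compound 2 to compound 3 (0.38 log units; beyond the scatter). Within the data shown here, this is the first direct reading at this position, and it shows that the saturated ring can give way to an aromatic ring carrying hydroxymethyl at only a modest cost. Nothing available explains the size of this step. The compounds shown leave open whether the hydroxymethyl group itself contributes, as plain phenyl is not among them. They also leave open how an amine or a carboxylic acid in its place would fare.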